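Amide nitrogen methylation in a substance-P receptor binding series

The source may hold more compounds than are shown below. What is called first, only, known or untested is meant among the compounds shown, and "the series" means these compounds.

Measured compounds:
Compound 1 `Cc1nccc(-c2ccccc2)c1C(=O)N(C)Cc1cc(C(F)(F)F)cc(C(F)(F)F)c1`: 98 nM
Compound 2 `Cc1nc(Cl)cc(-c2ccccc2)c1C(=O)N(C)Cc1cc(C(F)(F)F)cc(C(F)(F)F)c1`: 91 nM
Compound 3 `Cc1nc(N2CCN(C)CC2)cc(-c2ccccc2)c1C(=O)NCc1cc(C(F)(F)F)cc(C(F)(F)F)c1`: 53 nM

Among the compounds with values here, in an assay on CHO cells for displacement of a labelled ligand from Substance-P receptor (Homo sapiens), with a stated time of 90 min (on this read-out higher numbers stand for weaker inhibition and lower numbers for stronger inhibition), compound 1 gives 98 nM and compound 2 gives 91 nM; the single one-place step between them, a 1.1-fold lower number from compound 1 to compound 2 (0.03 log units; within the scatter), is chloro in place of hydrogen on an aromatic carbon. Compound 3 gives 53 nM in this assay ; this is the smallest of the three numbers, but its gaps to compound 2 and to compound 1 both lie within the scatter, so no order among the three is established.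

Compound 4 `Cc1nc(N2CCN(C)CC2)cc(-c2ccccc2)c1C(=O)N(C)Cc1cc(C(F)(F)F)cc(C(F)(F)F)c1` differs from compound 3 by methyl in place of hydrogen on an amide-type nitrogen. Within the data shown here, no measured one-place step covers this change: compound 1 and compound 2 carry the methylated amide nitrogen while compound 3 does not, but they differ from compound 3 in more than one place, so their values show only that both arrangements fall in the same range. With no bearing step beyond the scatter, no step beyond the scatter is expected in this assay ; the expected change is a 1.0-fold higher number from compound 3 to compound 4 (0.02 log units; within the scatter). Compound 4 is estimated at 55 nM, within 20 nM to 150 nM.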

Compound 4, half-maximal inhibitory concentration: 4.8 nM
Estimate against measurement, compound 4: 11-fold (1.06 log units) above; measured number below the stated range.
By their numbers in this assay, from the lowest: compound 4; then compounds 3, 2 and 1 (each within the scatter of the next).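

In this assay, methyl in place of the amide hydrogen is a large step once the 4-methylpiperazin-1-yl group is present: an 11-fold lower number from compound 3 to compound 4 (1.04 log units; beyond the scatter). Within the data shown here, the amide nitrogen is therefore a sensitive position, which no one-place step among the earlier compounds could show. With the methylated amide nitrogen held, the aromatic carbon is sensitive too, with a 19-fold lower number from compound 2 to compound 4 (1.28 log units; beyond the scatter) for 4-methylpiperazin-1-yl in place of chloro and a 20-fold lower number from compound 1 to compound 4 (1.31 log units; beyond the scatter) for the same group in place of hydrogen, whereas chloro in place of hydrogen stayed within the scatter.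

Going by these compounds, whether the methyl step holds on the chloro compound or the unsubstituted compound remains open, as does the outcome with an ethyl group on the amide nitrogen or a morpholine in place of 4-methylpiperazin-1-yl. Nothing available accounts for these steps.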